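Exchanging the aryl group on the sulfonyl sulfur

The source may hold more compounds than are shown below. What is called first, only, known or untested is meant among the compounds shown, and "the series" means these compounds.

Among the measured compounds shown here, compound 2 `COc1ccc(S(=O)(=O)NCCN2CCC(CCC(=O)c3cc(Cl)c(N)cc3OC)CC2)cc1Cl` gives 85% in an assay on HEK293 cells for displacement of a labelled ligand from 5-hydroxytryptamine receptor 6 (Homo sapiens), with a stated time of 60 min, tested at 1 uM, in the presence of a further agent that is not named here (a lower number here means a weaker effect, a higher number a stronger effect of the compound at the concentration tested), the higher of the two numbers known there. For the measured compounds named here, compound 1 `COc1cc(N)c(Cl)cc1C(=O)CCC1CCN(CCNS(=O)(=O)c2ccc(N)cc2)CC1`, with a 4-aminophenyl on the sulfonyl sulfur, gives 46% in this assay; the step of a number 39 percentage points higher from compound 1 to compound 2 (beyond the scatter) is the only measured step, and it shows that the group on the sulfonyl sulfur can move the readout a long way.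

Compound 3 `COc1cc(N)c(Cl)cc1C(=O)CCC1CCN(CCNS(=O)(=O)c2ccc(C)cc2)CC1` has not yet been measured. It differs from compound 2 as follows (4-methylphenyl in place of 3-chloro-4-methoxyphenyl on a sulfonyl sulfur).

The step from compound 1 to compound 2 bears on this change only in part: it tells how 3-chloro-4-methoxyphenyl compares with 4-aminophenyl, but nothing measured here tells how 4-methylphenyl compares with either. Going by the values given here, since the 3-chloro-4-methoxyphenyl that leaves is the one group tied to the high readout of compound 2, a fall beyond the scatter in this assay is expected, though smaller than a number 39 percentage points higher from compound 1 to compound 2 (beyond the scatter), so a number 23 percentage points lower from compound 2 to compound 3 (beyond the scatter) is the expected step. Compound 3 is therefore estimated at 62%, with a range from 38% to 84%.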

Compound 3, a percentage reported as inhibition, at one concentration (the size of the read-out at that concentration, not a potency): 15%
Compound 3: middle estimate off by 47 percentage points, on the high side; the measured number lies below the stated range.
By their numbers in this assay, from the lowest: compound 3; then compound 1; then compound 2.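

In this assay, among the compounds shown here, the 4-methylphenyl on the sulfonyl sulfur brings a number 70 percentage points lower from compound 2 to compound 3 (beyond the scatter) and so sits far under 3-chloro-4-methoxyphenyl, a wider spread at this position than the one earlier step could show. Methyl in place of amino on an aromatic carbon gives a number 31 percentage points lower from compound 1 to compound 3 (beyond the scatter) and thus moves 4-aminophenyl from the low end of the series to its middle, showing that one small exchange on this aromatic ring, with the rest of the molecule held constant, is enough to change the readout by a large amount. No measurement available here bears on why these three aryl groups differ so strongly.

The compounds shown do not separate the chlorine from the methoxy group of compound 2, so a 3-chlorophenyl or a 4-methoxyphenyl on the sulfonyl sulfur could lie anywhere in this range. They also leave open how a hydroxyl in place of the amino group of compound 1 would read, and whether a cyclohexyl or a pyridine ring can take the place of the phenyl ring at all.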